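A few compounds are considered here, and "the series" means these few. Any claim that something is new, unique, unknown or untested is made for them only; others in the source may bear on it.

Working notes on the series, values in an ADME assay on MRC5 cells (Homo sapiens) for cytotoxicity, read by fluorescence and resazurin assay, with a stated time of 3 days; a higher number here means that more compound is needed for the effect, a lower number that less compound is needed:
- compound 1 `CCOC(=O)Nc1ccc(S(=O)(=O)n2c(C3(O)C=CC(=O)C=C3)cc3ccccc32)cc1`: 86 nM
- compound 2 `COC(=O)CCc1ccc(S(=O)(=O)n2c(C3(O)C=CC(=O)C=C3)cc3ccccc32)cc1`: 280 nM
- compound 3 `O=C1C=CC(O)(c2cc3ccccc3n2S(=O)(=O)c2ccc(CCC(=O)N3CCOCC3)cc2)C=C1`: 67 nM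

Compound 2 stands highest of the three numbers. Compound 4 `Nc1nc(N)nc(NCCCOC(=O)CCc2ccc(S(=O)(=O)n3c(C4(O)C=CC(=O)C=C4)cc4ccccc43)cc2)n1` differs from it by 2-((4,6-diamino-1,3,5-triazin-2-yl)amino)ethyl in place of hydrogen on a saturated chain carbon bound to an oxygen next to a carbonyl group, with 2-((4,6-diamino-1,3,5-triazin-2-yl)amino)ethyl in place of hydrogen on a saturated chain carbon bound to an oxygen next to a carbonyl group. The closest measured change is morpholin-4-yl in place of methoxy on a carbonyl carbon, a 4.2-fold lower number from compound 2 to compound 3 (0.62 log units; beyond the scatter). The other change, a 3.3-fold higher number from compound 1 to compound 2 (0.51 log units; beyond the scatter), replaces the whole substituent and bears less. For the measured compounds named here, no measured compound carries the entering group, so the direction is tentative. A lower number is expected, of modest size at most, and the estimated step is a 1.9-fold lower number from compound 2 to compound 4 (0.27 log units; within the scatter). For compound 4 the estimated value is 150 nM, with an expected range of 50 nM to 450 nM.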

Compound 4, half-maximal effective concentration: 950 nM
For compound 4 the middle estimate is 6.3-fold (0.80 log units) below the measured one; measured number above the stated range.
By their numbers in this assay, from the lowest: compounds 3 and 1 (each within the scatter of the next); then compound 2; then compound 4.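

In this assay, 2-((4,6-diamino-1,3,5-triazin-2-yl)amino)ethyl in place of hydrogen on a saturated chain carbon bound to an oxygen next to a carbonyl group gives a 3.4-fold higher number from compound 2 to compound 4 (0.53 log units; beyond the scatter), the opposite direction to a 4.2-fold lower number from compound 2 to compound 3 (0.62 log units; beyond the scatter), the morpholin-4-yl change at the carbonyl carbon. Changes at this end of the side chain can therefore move the number either way. Nothing available accounts for this reversal.

Open, as far as these compounds go, is whether the triazine or the chain carries the step; 3-aminopropyl in place of methyl, or the free carboxylic acid, would bear on this.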